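The compounds below may be only part of what the source reports. "The series", "measured", "known", "first", "only" and "open" are said of these compounds alone.

Measured so far in a functional assay on the whole organism with Rattus norvegicus as the target, at a dose of 100 mg/kg; on this read-out higher numbers stand for more inhibition at the one dose given (going by the name of the read-out) and lower numbers for less inhibition:
compound 1, `C/N=C(\S)NCCCCn1nc(C)ccc1=O`, 44.5%
compound 2, `CC/N=C(/NC#N)NCCCn1nc(-c2ccccc2)cc(C)c1=O`, 23.5%
compound 3, `CC/N=C(\S)NCCCCCCn1nc(-c2ccccc2)ccc1=O`, -5.6%

Compound 3 stands lowest of the three numbers. Its nearest neighbour is compound 2, whose number lies higher by a gap beyond the scatter; furthest is compound 1, higher again by a gap beyond the scatter. Of the three, compound 1 therefore shows the most inhibition at the dose given and compound 3 the least, since each gap between them is beyond the scatter.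

The step to compound 4, `CC(C)(C)/N=C(\S)NCCCCn1nc(-c2ccccc2)ccc1=O`, keeps the same atoms as compound 3, joined differently: a group of 8 heavy atoms (5 carbon, 2 nitrogen, 1 sulfur; no ring) in place of a group of 8 heavy atoms (5 carbon, 2 nitrogen, 1 sulfur; no ring), on a saturated chain carbon, four bonds along the chain from an aromatic nitrogen. Within the data shown here, no pair of measured compounds differs in one place only, so no single step of this kind has been measured and the size of the change cannot be read from a matched pair.

In this assay compound 4 is expected to sit between compound 3 and compound 1, because compound 3 gives -5.6% while compound 1 gives 44.5% and compound 4 shares a chain of the same length with compound 1. The step from compound 3 to compound 4 is expected to be upward and beyond the scatter, a number 25.6 percentage points higher from compound 3 to compound 4 (beyond the scatter). For compound 4 the estimate is 20%, with a range from -5% to 45%.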

Compound 4, a percentage reported as inhibition, in the whole organism at one dose (the size of the read-out at that dose, not a potency): 33.6%
For compound 4 the middle estimate is 13.6 percentage points below the measured one; measured number inside the range.
By their numbers in this assay, from the lowest: compound 3; then compound 2; then compound 4; then compound 1.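

At the saturated chain carbon, four bonds along the chain from an aromatic nitrogen, one group of 8 heavy atoms (5 carbon, 2 nitrogen, 1 sulfur; no ring) in place of another gives a number 39.2 percentage points higher from compound 3 to compound 4 (beyond the scatter) in this assay as a large step. Among these compounds, this is the first single-place step, and the two groups have the same atoms and the same counts of donors and acceptors. At the one dose given, then, the read-out in this assay responds to how these atoms are joined, and identical composition does not fix the number. No evidence at hand bears on the reason for this step.

Since the two groups differ both in the chain and at the far end, this one step does not show how much of the change belongs to each part. Still open, as far as these compounds go, is where the number would fall with a cyclohexyl group at the far end of the group or with a pentyl chain at this position, and whether the step would carry over to a core with a different ring substituent.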